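Bromo for Dimethylamino on the Styryl Arm

This account rests on a few compounds, and the source may have more. Where it says the series, first, only, none or still open, it means among the compounds named here.

Three analogues of one shared core have been measured in a functional assay on DU-145 cells (Homo sapiens) for inhibition, read by trypan blue exclusion, with a stated time of 96 h; a higher number here means a weaker inhibitor of growth, a lower number a stronger inhibitor of growth. Compound 1 `Cc1ccc(CS(=O)(=O)/C(=C/c2c[nH]c3ccc(Br)cc23)C(=O)c2ccc(Cl)cc2)cc1` gives 10000 nM, compound 2 `CCOc1ccc(/C=C(\C(=O)c2ccc(Cl)cc2)S(=O)(=O)Cc2ccc(C)cc2)cc1OC` gives 10000 nM, and compound 3 `Cc1ccc(CS(=O)(=O)/C(=C/c2ccc(N(C)C)cc2)C(=O)c2ccc(Cl)cc2)cc1` gives 50000 nM, the highest number of the three; the steps of a 5.0-fold higher number from compound 1 to compound 3 (0.70 log units; beyond the scatter) and a 5.0-fold higher number from compound 2 to compound 3 (0.70 log units; beyond the scatter) set it apart, whereas no change at the digits printed from compound 1 to compound 2 (within the scatter) shows no change. Compound 4 `Cc1ccc(CS(=O)(=O)/C(=C/c2ccc(Br)cc2)C(=O)c2ccc(Cl)cc2)cc1` carries bromo in place of dimethylamino on an aromatic carbon. Both measured steps in which dimethylamino entered raised the number, so its replacement by bromo, a group already present in compound 1, is expected to lower the number by a similar amount, back toward compound 1 and compound 2. Compound 4 is therefore expected to give about 10000 nM, between 4000 nM and 30000 nM, which means an expected step of a 5.0-fold lower number from compound 3 to compound 4 (0.70 log units; beyond the scatter).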

Compound 4, concentration for 50% growth inhibition: 25000 nM
Beside the measured number, compound 4's estimate is 2.5-fold (0.40 log units) below it, within the range that was stated.
By their numbers in this assay, from the lowest: compounds 1 and 2 (each within the scatter of the next); then compounds 4 and 3 (each within the scatter of the next).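

On this aromatic carbon, bromo in place of dimethylamino gives a 2.0-fold lower number from compound 3 to compound 4 (0.30 log units; within the scatter), so the exchange does not separate these two groups. The 4-bromophenyl arm still stands apart from the two other arms, with a 2.5-fold higher number from compound 2 to compound 4 (0.40 log units; beyond the scatter) and a 2.5-fold higher number from compound 1 to compound 4 (0.40 log units; beyond the scatter), which suggests that the gap seen earlier does not depend on dimethylamino alone. Nothing here gives a measured reason for this result. Going by these compounds, how a methoxy, a primary amine or a carboxylic acid on this same aromatic carbon would read in this assay remains open.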